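A few compounds are considered here, and "the series" means these few. Any claim that something is new, unique, unknown or untested is made for them only; others in the source may bear on it.

Compound 3 `Cc1cc(CCC#N)cc(C)c1Oc1cc(Nc2ccc(C#N)cc2)c(N)cc1CNC1CC1` stands second highest of the three half-lives recorded in an ADME assay on liver for metabolic stability, with Liver microsome (Homo sapiens) as the target, read by LC-MS, using microsomes, tested at 1 uM; on this read-out higher numbers stand for a longer-lived compound and lower numbers for a shorter-lived compound: compound 3 gives 1.65 h. Its nearest neighbour is compound 1 `Cc1cc(CCC#N)cc(C)c1Oc1cc(Nc2ccc(C#N)cc2)c(N)cc1C(=O)NC1CC1`, which in this assay gives 1.05 h; the furthest is compound 2 `Cc1cc(CCC#N)cc(C)c1Oc1cc(Nc2ccc(C#N)cc2)c(N)cc1CN(C)C`, which gives 3.85 h. The steps among these three are all of modest size: a 1.6-fold higher number from compound 1 to compound 3 (0.20 log units; within the scatter), a 3.7-fold higher number from compound 1 to compound 2 (0.56 log units; beyond the scatter), and a 2.3-fold lower number from compound 2 to compound 3 (0.37 log units; beyond the scatter).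

Compound 4 `Cc1cc(CCC#N)cc(C)c1Oc1cc(Nc2ccc(C#N)cc2)c(N)cc1COC(=O)C1CC1` differs from compound 3 at the saturated chain carbon bound to an aromatic carbon, where ((cyclopropylcarbonyl)oxy in place of cyclopropylamino on a saturated chain carbon bound to an aromatic carbon). Within the data shown here, of the measured steps, only the one from compound 2 to compound 3 touches the same chain carbon, and it swaps one amine for another; the step from compound 1 to compound 3 exchanges an amide for an amine. Among the measured compounds shown here, neither covers an ester entering in place of an amine, so no measured step bears directly on this change. With the scatter in mind, a modest step in this assay is expected, more likely downward than upward, a 1.8-fold lower number from compound 3 to compound 4 (0.26 log units; within the scatter). Compound 4 is therefore estimated at 0.9 h, within a range of 0.3 h to 2.5 h.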

Compound 4, half-life: 0.195 h
Estimate against measurement, compound 4: 4.6-fold (0.66 log units) above, and the stated range ends above it.
By their numbers in this assay, from the lowest: compound 4; then compounds 1 and 3 (each within the scatter of the next); then compound 2.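

Among these compounds, at the saturated chain carbon bound to an aromatic carbon, in this assay, (cyclopropylcarbonyl)oxy in place of cyclopropylamino gives a far bigger drop than any difference among the amines (the step reads an 8.5-fold lower number from compound 3 to compound 4 (0.93 log units; beyond the scatter)), and in place of dimethylamino it gives the only step of large size in the set (a 20-fold lower number from compound 2 to compound 4 (1.30 log units; beyond the scatter)). Against the amide, ((cyclopropylcarbonyl)oxy)methyl in place of cyclopropylcarbamoyl also goes down (a 5.4-fold lower number from compound 1 to compound 4 (0.73 log units; beyond the scatter)), so compound 4 is the lowest of the four, with its steps to all three others beyond the scatter, whereas the amide and the two amines had shown that this place could shift the half-life only by modest steps. What lies behind the drop cannot be told here, as no supporting measurement accompanies these half-lives.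

The compounds shown leave open whether the drop belongs to the ester link itself or simply to the absence of an amine or amide at this carbon. An ether carrying the same cyclopropyl ring on this chain carbon, or an acetate ester in place of the cyclopropanecarboxylate, would help to separate those two readings.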